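Three Measured Compounds, One Untested Analogue

The source may report more compounds than this note shows. Statements on the series, on what has been measured and on what is new or still open speak of the compounds shown alone.

Compound 1 `O=C(Nc1ccc(O)cc1)c1ccc([N+](=O)[O-])o1`: > 20000 nM
Compound 2 `O=C(Nc1ccc(O)c(C(F)(F)F)c1)c1ccc([N+](=O)[O-])o1`: > 20000 nM
Compound 3 `C=CCOc1ccc(NC(=O)c2ccc([N+](=O)[O-])o2)cc1C(F)(F)F`: > 20000 nM

In an ADME assay on HeLa cells (Homo sapiens) for cytotoxicity, read by resazurin assay, with a stated time of 65 h (a higher number here means that more compound is needed for the effect, a lower number that less compound is needed), compound 1 gives only a limit, > 20000 nM. Compound 2 likewise gives only a limit in this assay, > 20000 nM. Compound 3 also reaches only a limit, > 20000 nM. Hence a step that the two limits leave unreadable from compound 2 to compound 1, a change of hydrogen in place of trifluoromethyl on an aromatic carbon, and a step that the two limits leave unreadable from compound 2 to compound 3, a change of allyl in place of hydrogen on an oxygen on an aromatic ring, because of the limit of > 20000 nM in this assay, at which 3 of the 3 values shown sit.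

Compound 4 `C=CCOc1ccc(NC(=O)c2ccc([N+](=O)[O-])o2)cc1` is not yet measured. It differs from compound 3 by hydrogen in place of trifluoromethyl on an aromatic carbon, the same kind of change as from compound 2 to compound 1, though here the place is ortho to an allyloxy group rather than ortho to a hydroxy group. Since compound 3 sits at > 20000 nM and compound 1 sits at > 20000 nM, compound 4 is expected to give 30000 nM, between 10000 nM and 100000 nM, an expected step that the limit leaves unreadable from compound 3 to compound 4.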

Compound 4, half-maximal effective concentration: > 20000 nM
Compound 4: no number, only a limit; the forecaster's own chance of this, stated with the estimate: 85%; the middle value does not contradict the limit.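

With compound 4 also giving only a limit, no step from compound 3 or compound 1 to compound 4 can be read in this assay, because of this: the limit of > 20000 nM in this assay, at which 4 of the 4 values shown sit. The compounds shown leave open what concentration gives the half-maximal effect for any of them, and whether either change alters it.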